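The source may report more compounds than this note shows. Statements on the series, on what has been measured and on what is new or still open speak of the compounds shown alone.

Measured so far:
compound 1, `CC(C)CCNc1c(O)cc2oc(-c3ccccc3)cc(=O)c2c1O`: 116 uM
compound 2, `CC(C)CCNc1c(O)cc(O)c2c(=O)cc(-c3ccccc3)oc12`: 16 uM

Working notes on the series. In an ADME assay on Hippocampus (Mus musculus), read by LDH release (a lower number here means that less compound is tolerated, a higher number that more compound is tolerated), compound 1 gives 116 uM, the higher of the two numbers recorded. Compound 2 gives 16 uM in this assay, a clearly lower number; the two structures differ in more than one place, so the comparison between them is only what the two values show, and no single step can be read from it.

The compound to be measured next is compound 3, `CCCNc1c(O)cc2oc(-c3ccccc3)cc(=O)c2c1O`. It differs from compound 1 in one place: methyl in place of isopropyl on a saturated chain carbon, two bonds along the chain from a nitrogen on an aromatic ring. The change is a shortening of the chain on the ring nitrogen, the rest of the shared core being unchanged.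

For the measured compounds named here, no measured step of this kind is available, so the size of the step must be guessed. With nothing else to go on, the expectation is a small shift, perhaps toward a somewhat higher number, that need not exceed the usual scatter. Compound 3 is accordingly expected to give about 140 uM in this assay, with a range of 60 uM to 330 uM, which corresponds to an expected step of a 1.2-fold higher number from compound 1 to compound 3 (0.08 log units; within the scatter).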

Compound 3, half-maximal toxic concentration: 176 uM
For compound 3 the middle estimate is 1.3-fold (0.10 log units) below the measured one; low and high end bracket the measured number.
By their numbers in this assay, from the lowest: compound 2; then compounds 1 and 3 (each within the scatter of the next).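

In this assay, methyl in place of isopropyl on a saturated chain carbon, two bonds along the chain from a nitrogen on an aromatic ring, gives a 1.5-fold higher number from compound 1 to compound 3 (0.18 log units; within the scatter). For the compounds shown here, this is the first single change that can be read, and it shows that going from isopentylamino to propylamino, with the shared core unchanged, does not separate the two compounds beyond what repeated measurements would give, so for this pair the branched end of the chain makes no readable difference to the tolerated concentration. No measured information bears on why the number behaves in this way.

Going by these compounds, one pair gives no trend along the chain, so it remains open whether a longer chain, a cyclopropylmethyl group or a terminal amine or carboxylic acid at this place would also stay within the scatter of compound 1. Also open, on these data alone, is whether the same change from isopentylamino to propylamino would read alike on the core of compound 2, which gives 16 uM and so far has no partner differing from it in one place.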